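Notes on trifluoromethyl position in the benzyl amide series

The source may hold more compounds than are shown below. What is called first, only, known or untested is meant among the compounds shown, and "the series" means these compounds.

Measured so far:
compound 1 `CCN(Cc1cccc(F)c1)C(=O)C1CCN(S(=O)(=O)c2ccc3cn[nH]c3c2)CC1` — 89%
compound 2 `CCN(Cc1ccccc1C(F)(F)F)C(=O)C1CCN(S(=O)(=O)c2ccc3cn[nH]c3c2)CC1` — 92%

In a functional assay on CHO cells for positive allosteric modulation of muscarinic acetylcholine receptor M5 (Homo sapiens), read by calcium flux (on this read-out higher numbers stand for larger maximal responses and lower numbers for smaller maximal responses), compound 1 gives 89%. In this assay, for the measured compounds named here, compound 2 gives 92%; the only measured step, a number 3 percentage points higher from compound 1 to compound 2 (within the scatter), leaves the two within the scatter of each other, so compound 2 stands level with compound 1 rather than apart from it. Compound 3 `CCN(Cc1cccc(C(F)(F)F)c1)C(=O)C1CCN(S(=O)(=O)c2ccc3cn[nH]c3c2)CC1` is not yet measured. It differs from compound 2 by 3-(trifluoromethyl)phenyl in place of 2-(trifluoromethyl)phenyl on a saturated chain carbon bound to an amide-type nitrogen. Going by the values given here, no measured step moves the trifluoromethyl group around its ring. Among the compounds with values here, the one step known, a number 3 percentage points higher from compound 1 to compound 2 (within the scatter), exchanges 3-fluorophenyl for 2-(trifluoromethyl)phenyl without leaving the scatter, and compound 1, itself carrying a 3-fluorophenyl, already reaches 89%. On that basis no step beyond the scatter is expected in this assay for compound 3; the expected step is a number 2 percentage points lower from compound 2 to compound 3 (within the scatter). Compound 3 is estimated at 90%, with a range from 76% to 102%.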

Compound 3, largest response reached (reported as percent of maximum), in percent of the reference or control that the assay uses: 59%
Beside the measured number, compound 3's estimate is 31 percentage points above it; measured number outside the range, below it.
By their numbers in this assay, from the lowest: compound 3; then compounds 1 and 2 (each within the scatter of the next).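

In this assay, for the compounds shown here, moving the trifluoromethyl group gives the first step beyond the scatter: 3-(trifluoromethyl)phenyl in place of 2-(trifluoromethyl)phenyl on a saturated chain carbon bound to an amide-type nitrogen gives a number 33 percentage points lower from compound 2 to compound 3 (beyond the scatter) even though the two compounds have the same atoms, so at this place the maximal response depends on how the group is joined to the ring and not only on which atoms are present. The change from fluoro to trifluoromethyl on an aromatic carbon also matters, giving a number 30 percentage points lower from compound 1 to compound 3 (beyond the scatter) and showing that a 3-fluorophenyl reaching a high response does not carry over to 3-(trifluoromethyl)phenyl. Nothing available explains either step.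

Going by these compounds, whether a methoxy group or a nitrile in place of fluoro on that aromatic carbon would stay level with compound 1 or fall toward compound 3 remains open. Also open, on these data alone, is whether the same drop would appear with a longer chain on the amide-type nitrogen.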